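The source may hold more compounds than are shown below. What is called first, only, known or untested is meant among the compounds shown, and "the series" means these compounds.

Compound 1 `COc1ccc(CN2CCN(c3ccc(C4CC(c5ccc([N+](=O)[O-])o5)=NO4)cc3)CC2)cn1` in an ADME assay on WI-38 cells (Homo sapiens) for cytotoxicity, read by MTT assay, with a stated time of 96 h (a lower number here means a stronger inhibitor, a higher number a weaker inhibitor), gives a limit of > 50000 nM. Compound 2 `O=[N+]([O-])c1ccc(C2=NOC(c3ccc(N4CCN(Cc5ccccn5)CC4)cc3)C2)o1` in this assay gives a limit of > 50000 nM. Compound 3 `O=[N+]([O-])c1ccc(C2=NOC(c3ccc(N4CCN(Cc5cccnc5)CC4)cc3)C2)o1` in this assay gives a limit of > 50000 nM.

Compound 3 thus stands at the limit of > 50000 nM in this assay, at which 3 of the 3 values shown sit, a limit rather than a number. Compound 4 `CC(C)(C)OC(=O)N1CCN(c2ccc(C3CC(c4ccc([N+](=O)[O-])o4)=NO3)cc2)CC1` differs from it by tert-butoxycarbonyl in place of (pyridin-3-yl)methyl on an amine nitrogen in a ring. The steps already measured, a step that the two limits leave unreadable from compound 1 to compound 2, a step that the two limits leave unreadable from compound 1 to compound 3 and a step that the two limits leave unreadable from compound 2 to compound 3, all lie between limits and cannot be read, so none of them shows how a change on the ring nitrogen moves this assay. The step expected in this assay is therefore a number no higher from compound 3 to compound 4 (the limit leaves the size open), with no direction beyond the scatter. Compound 4 is estimated at 50000 nM, from 20000 nM to 100000 nM, most probably reported once more as a limit.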

Compound 4, half-maximal inhibitory concentration: > 50000 nM
Compound 4: a limit, no number; the forecaster's own chance of this, stated with the estimate: 75%; the middle value lies on the limit itself.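

Compound 4, like compound 1, compound 2 and compound 3, gives a limit and not a number, so no step among these compounds can be read: the limit of > 50000 nM in this assay, at which 4 of the 4 values shown sit.

The compounds shown leave open whether any change on the ring nitrogen moves this assay.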